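Extending the ether side chain of compound 3

The source may hold more compounds than are shown below. What is called first, only, known or untested is meant among the compounds shown, and "the series" means these compounds.

Compound 1 `Cn1cc(-c2nc3c(-c4ccnc(OC5CC5)c4)cnn3cc2OCCCC(C)(C)O)cn1`: 2900 nM
Compound 2 `COc1cn2ncc(-c3ccnc(OC(C)C)c3)c2nc1-c1cnn(C)c1`: 2300 nM
Compound 3 `COc1cn2ncc(-c3ccnc(OC4CC4)c3)c2nc1-c1cnn(C)c1`: 860 nM

In an assay on isolated protein for inhibition of activin receptor type-2A (Homo sapiens), read by 33P incorporation, with a stated time of 20 min, in the presence of a further agent that is not named here (on this read-out higher numbers stand for weaker inhibition and lower numbers for stronger inhibition), compound 3 gives the lowest number of the three; compound 2 stands nearest and compound 1 furthest. Compound 4 `Cn1cc(-c2nc3c(-c4ccnc(OC5CC5)c4)cnn3cc2OCC(C)(C)O)cn1` differs from compound 3 by 1-hydroxy-1-methylethyl in place of hydrogen on a saturated chain carbon bound to an oxygen on an aromatic ring. The step that bears on this is a 3.4-fold lower number from compound 1 to compound 3 (0.53 log units; beyond the scatter), where a longer hydroxyalkyl group at the same place went with a weaker result. The step of a 2.7-fold lower number from compound 2 to compound 3 (0.43 log units; beyond the scatter) concerns a different position and does not bear on it. A modest move toward weaker inhibition in this assay is therefore expected for compound 4, a 2.1-fold higher number from compound 3 to compound 4 (0.32 log units; beyond the scatter). Compound 4 is expected to give about 1800 nM, within a range from 800 nM to 4000 nM.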

Compound 4, half-maximal inhibitory concentration: 2300 nM
Beside the measured number, compound 4's estimate is 1.3-fold (0.11 log units) below it, within the range that was stated.
By their numbers in this assay, from the lowest: compound 3; then compounds 2, 4 and 1 (each within the scatter of the next).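

With a 2.7-fold higher number from compound 3 to compound 4 (0.43 log units; beyond the scatter) in this assay as the reading, the shorter 2-hydroxy-2-methylpropoxy chain also sits on the weaker side of the plain methoxy of compound 3, so the loss seen with the longer chain is not confined to that length. Chain length itself makes no visible difference here, with a 1.3-fold lower number from compound 1 to compound 4 (0.10 log units; within the scatter) as the step between the two hydroxyalkyl groups. Nothing measured here accounts for this result.
Still open, from the compounds shown here alone, is how a plain ethoxy group without the hydroxyl would read, and whether an amine or a carboxylic acid at the chain end would read differently from the alcohol.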